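A few compounds are considered here, and "the series" means these few. Any claim that something is new, unique, unknown or untested is made for them only; others in the source may bear on it.

Compound 1 `CC1=NN(C(=O)c2ccc([N+](=O)[O-])cc2)C(c2ccccc2O)C1` gives 30100 nM; compound 2 `CC1=NN(C(=O)c2ccc(C)cc2)C(c2ccccc2O)C1` gives 11300 nM; compound 3 `CC1=NN(S(=O)(=O)c2ccc([N+](=O)[O-])cc2)C(c2cc(Br)cc(Br)c2O)C1` is reported as "not active" (no number reported).

All three were tested in a functional assay on HepG2 cells (Homo sapiens) for cytotoxicity, read by MTT assay, with a stated time of 48 h; on this read-out lower numbers stand for stronger inhibition and higher numbers for weaker inhibition. Going by the values given here, the only single-point change among them, (methyl in place of nitro on an aromatic carbon), brought a 2.7-fold lower number from compound 1 to compound 2 (0.43 log units; beyond the scatter). Compound 4 `CC1=NN(S(=O)(=O)c2ccc(C)cc2)C(c2cc(Br)cc(Br)c2O)C1` is related to compound 3 by the same change, (methyl in place of nitro on an aromatic carbon), at a place described in the same words as before. The difference between the two cores is not broken down here. Compound 3 has no number, only a report of no activity, so the earlier step cannot be applied to a measured value. Because the same change gave a 2.7-fold lower number from compound 1 to compound 2 (0.43 log units; beyond the scatter), compound 4 is expected to show a step of similar modest size, which may still leave it without a number. Compound 4 is estimated at 80000 nM, likely between 20000 nM and 300000 nM.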

Compound 4, half-maximal inhibitory concentration: "not active" (no number reported)
For compound 4 the study gives words and no number, and the estimate cannot be compared.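

Compound 3 and compound 4 are both reported only in words, as not active, so no step can be read between them. On these data alone, what methyl in place of nitro does on their shared core stays open. No measurement shown here bears on this result.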